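Benzyl ester aryl substituent and calcium channel antagonism

This account rests on a few compounds, and the source may have more. Where it says the series, first, only, none or still open, it means among the compounds named here.

Working notes on the benzyl ester position of the shared core. Compound 1 `COC(=O)C1=C(C)NC(C)=C(C(=O)OCc2ccccc2)C1c1cccc([N+](=O)[O-])c1` gives 25 nM in a functional assay on HEK293 cells for antagonist activity at Voltage-dependent L-type calcium channel subunit alpha-1C (Oryctolagus cuniculus), read by FLIPR; on this read-out lower numbers stand for stronger inhibition and higher numbers for weaker inhibition. Within the data shown here, compound 2 `COC(=O)C1=C(C)NC(C)=C(C(=O)OCc2ccc(F)c(F)c2)C1c1cccc([N+](=O)[O-])c1` gives 7 nM in this assay and so stands with the lowest of the two numbers measured so far; the single measured step, a 3.6-fold lower number from compound 1 to compound 2 (0.55 log units; beyond the scatter), separates it from compound 1. Compound 3 `COC(=O)C1=C(C)NC(C)=C(C(=O)OCc2ccc(OC)cc2)C1c1cccc([N+](=O)[O-])c1` is not yet measured. It differs from compound 2 by 4-methoxyphenyl in place of 3,4-difluorophenyl on a saturated chain carbon bound to an oxygen next to a carbonyl group. Among the measured compounds shown here, the only step that bears on this position is a 3.6-fold lower number from compound 1 to compound 2 (0.55 log units; beyond the scatter), which is the sole evidence for how an exchange of the aryl group at this place shifts the number, and it was modest though beyond the scatter. For compound 3 the number in this assay is expected to fall between the values seen for compound 1 and compound 2. The expected step in this assay is a 2.1-fold higher number from compound 2 to compound 3 (0.33 log units; beyond the scatter). The estimate for compound 3 is 15 nM, with a range from 5 nM to 45 nM.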

Compound 3, half-maximal inhibitory concentration: 51 nM
Compound 3: the middle estimate sits 3.4-fold (0.53 log units) below what was measured; measured number above the stated range.
By their numbers in this assay, from the lowest: compound 2; then compound 1; then compound 3.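

In this assay, the aryl group on a saturated chain carbon bound to an oxygen next to a carbonyl group can move the number either way relative to the phenyl of compound 1: methoxy in place of hydrogen on an aromatic carbon gives a 2.0-fold higher number from compound 1 to compound 3 (0.31 log units; beyond the scatter), the opposite direction to a 3.6-fold lower number from compound 1 to compound 2 (0.55 log units; beyond the scatter). The exchange of 3,4-difluorophenyl for 4-methoxyphenyl gives a 7.3-fold higher number from compound 2 to compound 3 (0.86 log units; beyond the scatter), which leaves the unsubstituted phenyl of compound 1 in the middle of the three. Nothing at hand explains the gap between the two substituted rings.

The compounds shown do not separate the kind of substituent from the number of substituents, since the two rings differ in both. On these data alone, whether a single fluorine, a hydroxy group or an amine on this ring would lie nearer compound 2 or compound 3 remains open.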